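The compounds below may be only part of what the source reports. "The series", "measured", "known", "first", "only" and "open" are said of these compounds alone.

Measured so far in a functional assay on SAOS-2 cells (Homo sapiens) for antiproliferative activity, read by MTT assay, with a stated time of 72 h; on this read-out lower numbers stand for stronger inhibition and higher numbers for weaker inhibition:
compound 1 `CCCCCOC1=C(C(=O)c2ccccc2)C(c2ccc(Br)cc2)N(CCCn2ccnc2)C1=O`, 9990 nM
compound 2 `Cc1ccc(NC2=C(C(=O)c3ccccc3)C(c3ccc(Br)cc3)N(CCCn3ccnc3)C2=O)cc1`, 31900 nM
compound 3 `O=C(C1=C(Nc2ccc(Br)cc2)C(=O)N(CCCn2ccnc2)C1c1ccc(Br)cc1)c1ccccc1`, 23800 nM

Compound 3 gives the second highest of these three numbers. Its nearest neighbour is compound 2, and the change a 1.3-fold lower number from compound 2 to compound 3 (0.13 log units; within the scatter) stays within the scatter; the step of a 2.4-fold higher number from compound 1 to compound 3 (0.38 log units; beyond the scatter) lies beyond it. Compound 4 `O=C(C1=C(Nc2cccc(Br)c2)C(=O)N(CCCn2ccnc2)C1c1ccc(Br)cc1)c1ccccc1` differs from compound 3 by 3-bromophenyl in place of 4-bromophenyl on an amine nitrogen. Among the compounds with values here, no measured step moves a substituent around that ring, so nothing bears directly on this change; the closest comparison, a 1.3-fold lower number from compound 2 to compound 3 (0.13 log units; within the scatter), swaps one substituent for another on the same ring and stays within the scatter. On that basis the expected step of a 1.1-fold higher number from compound 3 to compound 4 (0.02 log units; within the scatter) is none beyond the scatter. Compound 4 is therefore expected to give about 25000 nM in this assay, within a range of 10000 nM to 60000 nM.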

Compound 4, half-maximal inhibitory concentration: 9090 nM
Compound 4: the middle estimate sits 2.8-fold (0.44 log units) above what was measured, outside the stated range (below it).
By their numbers in this assay, from the lowest: compounds 4 and 1 (each within the scatter of the next); then compounds 3 and 2 (each within the scatter of the next).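

In this assay, the place of the bromo on the ring carried by the amine nitrogen matters: 3-bromophenyl in place of 4-bromophenyl gives a 2.6-fold lower number from compound 3 to compound 4 (0.42 log units; beyond the scatter) and so moves the number more than the earlier swap of methyl for bromo did. Replacing 4-methylphenyl with 3-bromophenyl gives a 3.5-fold lower number from compound 2 to compound 4 (0.55 log units; beyond the scatter) as well, while replacing pentyloxy with (3-bromophenyl)amino gives only a 1.1-fold lower number from compound 1 to compound 4 (0.04 log units; within the scatter) on the double-bonded ring carbon. Nothing available explains why the place of the bromo counts.

Going by these compounds, whether a chloro or methoxy group in place of this bromo would give a similar number remains open.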